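The source may hold more compounds than are shown below. What is called first, only, known or untested is meant among the compounds shown, and "the series" means these compounds.

Working notes on the series

Three compounds have been run in a functional assay on PC-3 cells (Homo sapiens) for cytotoxicity, read by sulforhodamine B assay, with a stated time of 48 h; on this read-out lower numbers stand for stronger inhibition and higher numbers for weaker inhibition. Compound 1 `CC(=O)N1N=C(c2cccc3ccccc23)CC1c1ccccc1` gives 8460 nM. Compound 2 `COc1ccc(OC)c(C2CC(c3cccc4ccccc34)=NN2C(C)=O)c1` gives 1980 nM. Compound 3 `COc1cc(C2CC(c3ccc4ccccc4c3)=NN2CC=O)cc(OC)c1OC` gives 570 nM, the lowest of the three numbers; the gap to compound 2 and the larger gap to compound 1 both lie beyond the scatter, so compound 3 reads as the most potent of the measured set. Going by the values given here, no two measured compounds differ in one place only, so no single change can be read off directly from these numbers.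

The next compound, compound 4 `COc1ccc(C2CC(c3ccc4ccccc4c3)=NN2CC=O)cc1OC`, is derived from compound 3 by one change: hydrogen in place of methoxy on an aromatic carbon. The methoxy-bearing six-membered ring of compound 3 thus keeps two methoxy groups while losing a third. Among the compounds with values here, no measured pair shows the removal of one methoxy on its own, so the size of this step is not anchored by data. The expectation is a modest loss in this assay, a step from compound 3 to compound 4 of about a 2.1-fold higher number from compound 3 to compound 4 (0.32 log units; beyond the scatter), which could also come out within the scatter. Compound 4 is therefore estimated at 1200 nM, with a likely range from 400 nM to 4000 nM.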

Compound 4, half-maximal inhibitory concentration: 1980 nM
The estimate for compound 4 lay 1.7-fold (0.22 log units) below the measured number; low and high end bracket the measured number.
By their numbers in this assay, from the lowest: compound 3; then compounds 2 and 4 (each within the scatter of the next); then compound 1.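

Working notes, continued

In this assay, going by these compounds alone, hydrogen in place of methoxy on this aromatic carbon gives a 3.5-fold higher number from compound 3 to compound 4 (0.54 log units; beyond the scatter) and is the first step that can be read between two compounds differing in one place. This methoxy, which sits ortho to a methoxy group and meta to a large group, therefore has a measurable bearing on the number even though the two other methoxy groups stay in place, and the step is modest rather than large. The data on hand offer no independent measurement that would explain this step.

The compounds shown leave open whether this position responds to the methoxy group specifically or would accept another substituent, such as a hydroxy group, a fluorine, an amine or a longer ether chain like ethoxy. They also leave open whether the same step would have a similar size on a different core, as one pair on one core gives a single reading and no general rule for the series.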